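The compounds below may be only part of what the source reports. "The series", "measured", "known", "first", "only" and "open" are said of these compounds alone.

Working notes on the series in an assay on membranes from brain for displacement of a labelled ligand from adenosine receptor A1 (Rattus norvegicus); a lower number here means a stronger inhibitor, a higher number a weaker inhibitor. Compound 1 `O=[N+]([O-])c1ccc(-c2nc3ccccn3c2NC2CCCCC2)cc1` carries nitro on an aromatic carbon of the six-membered aromatic ring of carbon only; in this assay compound 1 returns > 100000 nM, which is a limit of the assay rather than a number. Compound 2 `COc1ccc(-c2nc3ccccn3c2NC2CCCCC2)cc1` carries methoxy at the same place; in this assay compound 2 gives 7610 nM. Among the compounds with values here, the one measured step is an at least 13-fold lower number from compound 1 to compound 2 (1.11 log units; beyond the scatter). Within the data shown here, compound 2 therefore holds the only number measured in this assay, the other value being (the limit of > 100000 nM in this assay, at which 1 of the 2 values shown sits).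

Compound 3 `Cc1ccc(-c2nc3ccccn3c2NC2CCCCC2)cc1` is not yet measured. It differs from compound 2 by methyl in place of methoxy on an aromatic carbon. Among the measured compounds shown here, the single measured step concerns nitro against methoxy and not methoxy against methyl, so it bears on this change only indirectly; no step between methoxy and methyl exists. With nothing more to go on, a step of a 1.1-fold higher number from compound 2 to compound 3 (0.02 log units; within the scatter) is expected, that is, no change beyond the scatter. Compound 3 is estimated at 8000 nM, with a range from 2500 nM to 30000 nM.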

Compound 3, inhibition constant: 2060 nM
Compound 3: the middle estimate sits 3.9-fold (0.59 log units) above what was measured; measured number outside the range, below it.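

In this assay the place para to a large group on the six-membered aromatic ring of carbon only proves sensitive to more than the change away from nitro: methyl in place of methoxy gives a 3.7-fold lower number from compound 2 to compound 3 (0.57 log units; beyond the scatter) and so separates two small groups beyond the scatter. The hydrogen-bond acceptor counted on methoxy is therefore not required at this place for a measurable value, and compound 3, which has no acceptor in this group, now holds the lowest number of the three compounds. The step away from nitro widens to an at least 48-fold lower number from compound 1 to compound 3 (1.68 log units; beyond the scatter) and rests on a limit of the assay, not on a number: the limit of > 100000 nM in this assay, at which 1 of the 3 values shown sits.

With only nitro, methoxy and methyl at this place, the compounds shown leave open how chlorine, an amine, a carboxylic acid or a longer chain such as ethyl would read in this assay. Also open, on these data alone, is whether methyl would keep its lead over methoxy at another place on the same ring, as all three compounds carry their group at this one place.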